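Oxan-4-yl Amide in Place of Methylcyclopropyl Amide

This account rests on a few compounds, and the source may have more. Where it says the series, first, only, none or still open, it means among the compounds named here.

Compound 1 `CC1CC1C(=O)N1CCc2nc(C#Cc3ccccc3)sc2C1` was tested in an assay on HEK293 cells for positive allosteric modulation of metabotropic glutamate receptor 5 (Homo sapiens), read by FLIPR, with a stated time of 1 h (a lower number here means that less compound is needed, a higher number that more compound is needed for the effect), and gave 9.4 nM. Among the measured compounds shown here, of the two compounds measured so far, compound 1 has the higher number: compound 2 `O=C(C1CC(F)(F)C1)N1CCc2nc(C#Cc3cccc(F)c3)sc2C1` gives 2.5 nM in this assay, a gap beyond the usual scatter. Compound 3 `O=C(C1CCOCC1)N1CCc2nc(C#Cc3ccccc3)sc2C1` is still unmeasured. It differs from compound 1 in one place only: oxan-4-yl in place of 2-methylcyclopropyl on a carbonyl carbon. For the measured compounds named here, no measured pair shows this particular change, so the expected step of a 2.1-fold higher number from compound 1 to compound 3 (0.33 log units; beyond the scatter) rests on the structures alone and is taken as a modest move toward a higher number. Compound 3 is thus expected to give about 20 nM in this assay, within 6 nM to 70 nM.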

Compound 3, half-maximal effective concentration: 290 nM
For compound 3 the middle estimate is 15-fold (1.16 log units) below the measured one, outside the stated range (above it).
By their numbers in this assay, from the lowest: compound 2; then compound 1; then compound 3.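

Oxan-4-yl in place of 2-methylcyclopropyl on a carbonyl carbon gives a 31-fold higher number from compound 1 to compound 3 (1.49 log units; beyond the scatter), the first single-place change seen at this position. With the rest of compound 1 held fixed, this group alone moves the number by a large step, so the two rings are not interchangeable here. No measurement at hand accounts for the size of this step.

The compounds shown leave open whether the step goes with the ring oxygen or with the larger ring. Cyclohexyl on the same carbonyl carbon would separate the two.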